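This account rests on a few compounds, and the source may have more. Where it says the series, first, only, none or still open, it means among the compounds named here.

Compound 1, `COc1ccc(-c2cc3ccccc3nc2/C=C/C(=O)c2ccccc2)cc1`, was tested in a functional assay on NCI-H1299 cells (Homo sapiens) for antiproliferative activity, read by XTT assay, with a stated time of 72 h (on this read-out higher numbers stand for weaker inhibition and lower numbers for stronger inhibition), where compound 1 gives 1410 nM. Its companion compound 2, `COc1ccc(-c2cc3ccccc3nc2/C=C/C(=O)c2ccc(Br)s2)cc1`, gives 710 nM in this assay. Among the compounds with values here, of the two numbers measured so far, that of compound 1 is the higher, yet the gap, a 2.0-fold lower number from compound 1 to compound 2 (0.30 log units; within the scatter), lies within the scatter of repeated measurements, so the two compounds cannot be told apart on this evidence.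

The unmeasured compound 3, `COc1ccc(-c2cc3ccccc3nc2/C=C/C(=O)c2sccc2N)cc1`, differs from compound 1 in the same region: 3-aminothiophen-2-yl in place of phenyl on a carbonyl carbon. Within the data shown here, the one measured step that bears on this change is the one from compound 1 to compound 2, which also swaps phenyl on the carbonyl carbon for a five-membered aromatic ring with 1 hetero atom, and that step, a 2.0-fold lower number from compound 1 to compound 2 (0.30 log units; within the scatter), stayed within the scatter. Among the measured compounds shown here, the new group brings 1 hydrogen-bond donor and 2 hydrogen-bond acceptors where phenyl had none, but no measured pair speaks to that, so no step beyond the scatter is expected.

The step from compound 1 to compound 3 is therefore estimated at a 1.4-fold lower number from compound 1 to compound 3 (0.15 log units; within the scatter). Compound 3 is expected to give about 1000 nM in this assay, with a likely range from 400 nM to 2500 nM.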

Compound 3, half-maximal inhibitory concentration: > 10000 nM
Compound 3: no number, only a limit; the forecaster's own chance of this, stated with the estimate: 5%; middle value at least 10-fold (1.00 log units) away from the limit.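

Before this result, the only step at this position was a 2.0-fold lower number from compound 1 to compound 2 (0.30 log units; within the scatter), which gave no sign that the group on the carbonyl carbon matters in this assay. Compound 3 changes that picture, with an at least 7.0-fold higher number from compound 1 to compound 3 (0.85 log units; beyond the scatter) and an at least 14-fold higher number from compound 2 to compound 3 (1.14 log units; beyond the scatter), and compound 2 and compound 3 both carry a five-membered aromatic ring with 1 hetero atom, so the ring type alone does not settle the outcome and what the ring carries makes a large difference. The reading for compound 3 is a limit of the assay and not a number, so these steps give only a minimum size: the limit of > 10000 nM in this assay, at which 1 of the 3 values shown sits.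

The compounds shown do not separate the amine itself from its place on the ring, and an unsubstituted thiophen-2-yl, a 3-methylthiophen-2-yl or a 3-hydroxythiophen-2-yl would each bear on that question. They also leave open how weak compound 3 really is, and whether an amine on a phenyl ring in this same place would give a similar result.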